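A few compounds are considered here, and "the series" means these few. Any claim that something is new, unique, unknown or untested is made for them only; others in the source may bear on it.

Compound 1 `O=C(/C=C/c1ccc([N+](=O)[O-])o1)c1ccc(Cl)cc1` gives 558000 nM in a toxicity assay on Vero cells (Chlorocebus sabaeus) for cytotoxicity; a lower number here means that less compound is tolerated, a higher number that more compound is tolerated. Compound 2 `O=C(/C=C/c1ccc([N+](=O)[O-])o1)c1ccc(OCc2ccccc2)cc1` gives 515000 nM in this assay, so compound 2 stands alongside compound 1 within the usual scatter, the two numbers not separated. Compound 3 `O=C(/C=C/c1ccc([N+](=O)[O-])o1)c1ccc(OCc2ccc(Cl)cc2Cl)cc1` carries 2,4-dichlorophenyl in place of phenyl on a saturated chain carbon bound to an oxygen on an aromatic ring, a change on the benzyloxy group that entered with compound 2. Among the compounds with values here, the only step that bears on this region, a 1.1-fold lower number from compound 1 to compound 2 (0.03 log units; within the scatter), stayed within the scatter, so compound 3 is expected to show a 1.0-fold lower number from compound 2 to compound 3 (0.01 log units; within the scatter). Compound 3 is accordingly estimated at 500000 nM, with a range from 250000 nM to 1000000 nM.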

Compound 3, half-maximal cytotoxic concentration: 340000 nM
Beside the measured number, compound 3's estimate is 1.5-fold (0.17 log units) above it, and the stated range covers the measured number.
By their numbers in this assay, from the lowest: compounds 3, 2 and 1 (each within the scatter of the next).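

In this assay the change from phenyl to 2,4-dichlorophenyl on a saturated chain carbon bound to an oxygen on an aromatic ring gives a 1.5-fold lower number from compound 2 to compound 3 (0.18 log units; within the scatter) and so does not separate the two compounds. This step tests the ring of the benzyloxy group itself, whereas the earlier step only exchanged chloro for the whole benzyloxy group. No measurement available here bears on this result.

From the compounds shown here alone, whether an amine or a carboxylic acid on this ring, or a longer chain in place of benzyl, would give a step beyond the scatter stays open. Going by these compounds, what a single chlorine on this ring would give also stays open.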